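A few compounds are considered here, and "the series" means these few. Any claim that something is new, unique, unknown or untested is made for them only; others in the source may bear on it.

Values in a functional assay on HepG2 cells (Homo sapiens) for inhibition, read by MTT assay, with a stated time of 72 h; on this read-out higher numbers stand for weaker inhibition and lower numbers for stronger inhibition:
- Compound 1, `O=C(Nc1cccc(F)c1)C1CCN(C/C=C/c2ccccc2)CC1`: 51100 nM
- Compound 2, `O=C(Nc1ccc(F)c(Br)c1)C1CCN(C/C=C/c2ccccc2)CC1`: 8190 nM

Compound 2 holds the lower of the two numbers in this assay, at 8190 nM. The next compound, compound 3, `O=C(Nc1nccs1)C1CCN(C/C=C/c2ccccc2)CC1`, has 1,3-thiazol-2-yl in place of 3-bromo-4-fluorophenyl on an amide-type nitrogen.

Going by the values given here, only one measured step bears on this change: a 6.2-fold lower number from compound 1 to compound 2 (0.80 log units; beyond the scatter). It is modest but beyond the scatter, and it was made at the same place, with 3-bromo-4-fluorophenyl in place of 3-fluorophenyl. Among the compounds with values here, no measured compound carries 1,3-thiazol-2-yl, so this step is only a guide to size. It shows that a change at this place can move the number, but not where this particular group will fall.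

Compound 3 gives up the group found in compound 2, so a modest move to a higher number is expected rather than no change. The expected step is a 4.3-fold higher number from compound 2 to compound 3 (0.63 log units; beyond the scatter). For compound 3 the estimated value is 35000 nM, with an estimated range of 11000 nM to 100000 nM.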

Compound 3, half-maximal inhibitory concentration: 22400 nM
For compound 3 the middle estimate is 1.6-fold (0.19 log units) above the measured one, and the stated range covers the measured number.
By their numbers in this assay, from the lowest: compound 2; then compound 3; then compound 1.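

Working notes on the amide-type nitrogen: in this assay, 1,3-thiazol-2-yl places compound 3 inside the span set by the two phenyl-bearing compounds, with one step up (a 2.7-fold higher number from compound 2 to compound 3 (0.44 log units; beyond the scatter)) and one step down (a 2.3-fold lower number from compound 1 to compound 3 (0.36 log units; beyond the scatter)). The earlier pair varied only the substituents on a six-membered aromatic ring of carbon only, whereas this result shows that the position also accepts a five-membered aromatic ring with 2 hetero atoms and still gives a measurable number. The swap does not beat 3-bromo-4-fluorophenyl, but it does give a lower number than 3-fluorophenyl, so the order at this position is not simply phenyl-bearing groups on one side and the heteroaromatic group on the other; no measurement on hand accounts for this order.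

The compounds shown leave open whether a bromine on the 1,3-thiazol-2-yl ring would lower the number further, as well as how a pyridin-2-yl ring or a plain alkyl chain on the same nitrogen would rank. The separate contributions of the bromine and the fluorine in compound 2 also remain unresolved.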